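A few compounds are considered here, and "the series" means these few. Any claim that something is new, unique, unknown or untested is made for them only; others in the source may bear on it.

Measured compounds:
- compound 1, `COc1ccc(-c2oc3c(CC=C(C)C)c(OC(C)C(=O)O)cc(O)c3c(=O)c2O)cc1`: 19300 nM
- compound 2, `COc1ccc(-c2oc3c(CC=C(C)C)c(OC/C=C/C(=O)O)cc(O)c3c(=O)c2O)cc1`: "not determined" (no result reported)
- compound 3, `COc1ccc(-c2oc3c(CC=C(C)C)c(OC/C=C/C(=O)O)cc(O)c3c(=O)c2OC/C=C/C(=O)O)cc1`: "not determined" (no result reported)

These three compounds share one core and were tested in an ADME assay on Vero cells (Chlorocebus sabaeus) for cytotoxicity, read by MTT assay; a lower number here means a stronger inhibitor, a higher number a weaker inhibitor. Only compound 1 gives a number in this assay, namely 19300 nM. For compound 2 the result in this assay is "not determined" (no result reported), so no number is known for it, and compound 3 stands in the same position with "not determined" (no result reported). Compound 2 therefore cannot be placed against compound 1 on a numerical scale; all that can be said is that a close relative of the same core gave a weak signal in this assay.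

The next compound, compound 4, `CCOC(=O)COc1cc(O)c2c(=O)c(O)c(-c3ccc(OC)cc3)oc2c1CC=C(C)C`, is not yet measured. It differs from compound 2 in one place: ethoxycarbonyl in place of 2-carboxyethenyl on a saturated chain carbon bound to an oxygen on an aromatic ring. Among the compounds with values here, no measured pair here shows what such a change does in this assay, so the size of the step from compound 2 to compound 4 cannot be taken from the data; the expectation is for no movement beyond the usual scatter, with the weak signal of compound 1 at 19300 nM as the only anchor. For compound 4 the expected value in this assay is 20000 nM, within a range from 6000 nM to 70000 nM.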

Compound 4, half-maximal inhibitory concentration: 1400 nM
Beside the measured number, compound 4's estimate is 14-fold (1.15 log units) above it; the measured number lies below the stated range.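

Within the data shown here, the group carried on this oxygen clearly matters in this assay: replacing 1-carboxyethyl with (ethoxycarbonyl)methyl gives a 14-fold lower number from compound 1 to compound 4 (1.14 log units; beyond the scatter), so the series now has a first measured change at this position, and it is one beyond the usual scatter. Among these compounds, the steps from compound 2 and compound 3 to compound 4 cannot be read, as neither of those compounds has a number, so this single step is the only measured guide to the position. Nothing at hand explains why the number falls.

This one change alters two things at once, the carboxylic acid at the end of the group and the chain that carries it, so the compounds shown leave open which of the two accounts for the step; a carboxymethyl group on the same oxygen would help to separate them. From the compounds shown here alone, how an amide or a longer chain at this place would read also stays open, as does whether the same step would appear with the hydroxyl group on the rest of the shared core replaced.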